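Methylcarbamoyl in place of chloro on the distal ring

The compounds below may be only part of what the source reports. "The series", "measured", "known", "first", "only" and "open" are said of these compounds alone.

Compound 1 `Cc1oc(C(=O)O)cc1COc1ccc(-c2ccc(Cl)cc2)cc1` holds the lowest of the two numbers in an assay on cells for displacement of a labelled ligand from prostaglandin E2 receptor EP4 subtype (Homo sapiens), read by scintillation counting (on this read-out higher numbers stand for weaker inhibition and lower numbers for stronger inhibition), giving 1000 nM. Compound 2 `COc1ccccc1-c1ccc(OCc2cc(C(=O)O)oc2C)cc1` gives 1600 nM in this assay, and a 1.6-fold higher number from compound 1 to compound 2 (0.20 log units; within the scatter). Compound 3 `Cc1oc(C(=O)O)cc1COc1ccc(-c2ccncc2)cc1` gives > 10000 nM, which is a limit of the assay and not a number (the limit of > 10000 nM in this assay, at which 1 of the 3 values shown sits). Compound 4 `CNC(=O)c1ccc(-c2ccc(OCc3cc(C(=O)O)oc3C)cc2)cc1` differs from compound 1 by methylcarbamoyl in place of chloro on an aromatic carbon. For the measured compounds named here, two measured steps bear on this change: a 1.6-fold higher number from compound 1 to compound 2 (0.20 log units; within the scatter), while an at least 10-fold higher number from compound 1 to compound 3 (1.00 log units; beyond the scatter). A swap on that ring can therefore be neutral or costly. For compound 4 a higher number in this assay is expected, a 3.0-fold higher number from compound 1 to compound 4 (0.48 log units; beyond the scatter). Compound 4 is estimated at 3000 nM, with a range from 1000 nM to 10000 nM.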

Compound 4, inhibition constant: > 10000 nM
Compound 4 was reported as a limit; the forecaster's own chance of this, stated with the estimate: 15%; middle value at least 3.3-fold (0.52 log units) from the limit.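

Keeping the six-membered aromatic ring of carbon only and changing just the group para to a large group is still costly: an at least 10-fold higher number from compound 1 to compound 4 (1.00 log units; beyond the scatter) in this assay. The loss seen with compound 3 therefore does not require replacing the whole ring. Compound 4 gives a limit of the assay and not a number, so the full size of this step cannot be read: the limit of > 10000 nM in this assay, at which 2 of the 4 values shown sit.

The compounds shown do not separate the amide hydrogen from the other atoms of methylcarbamoyl. Dimethylcarbamoyl or a nitrile at this place would bear on that question.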